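The compounds below may be only part of what the source reports. "The series", "measured", "known", "first", "only" and "open" are said of these compounds alone.

In an assay for inhibition of alpha-N-acetylgalactosaminidase (Gallus gallus), tested at 1000 uM (on this read-out lower numbers stand for less inhibition and higher numbers for more inhibition at the one concentration tested (going by the name of the read-out)), compound 3 `O=C(O)[C@H]1NC[C@H](O)[C@@H](O)[C@H]1O` gives 31%, the highest of the three numbers, although compound 1 `O=C(O)[C@H]1NC[C@H](O)[C@H](O)[C@H]1O` with 21% sits inside the usual scatter of it, and only compound 2 `O=C(O)[C@H]1NC[C@@H](O)[C@@H](O)[C@@H]1O` with 3.8% lies clearly lower. Compound 4 `O=C(O)[C@H]1NC[C@@H](O)[C@H](O)[C@@H]1O` differs from compound 3 as follows: the two compounds have the same atoms and bonds and differ only in configuration as drawn: 3 of 4 stereo elements differ; a stereocentre at a saturated ring carbon is drawn S in compound 3 and R in compound 4; a stereocentre at a saturated ring carbon is drawn R in compound 3 and S in compound 4; a stereocentre at a saturated ring carbon is drawn S in compound 3 and R in compound 4. Going by the values given here, the same kind of change, all three hydroxyl-bearing centres inverted, appears in a number 17.2 percentage points lower from compound 1 to compound 2 (beyond the scatter), while the single inversion in a number 10 percentage points higher from compound 1 to compound 3 (within the scatter) and the double inversion in a number 27.2 percentage points higher from compound 2 to compound 3 (beyond the scatter) set the scale. Compound 4 also shares three of four configurations with compound 2, so a modest drop to the range of that compound is expected, a number 23 percentage points lower from compound 3 to compound 4 (beyond the scatter). Compound 4 is therefore estimated at 8% in this assay, between 0% and 25%.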

Compound 4, a percentage reported as inhibition, at one concentration (the size of the read-out at that concentration, not a potency): 11%
Estimate against measurement, compound 4: 3 percentage points below, within the range that was stated.
By their numbers in this assay, from the lowest: compounds 2, 4, 1 and 3 (each within the scatter of the next, the first and the last beyond it).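

In (the read-out this assay) the triple inversion gives a second step beyond the scatter (a number 20 percentage points lower from compound 3 to compound 4 (beyond the scatter)) in the same direction as the earlier one (a number 17.2 percentage points lower from compound 1 to compound 2 (beyond the scatter)). Fewer inversions leading to compound 4 stay within the scatter, for one centre (a number 7.2 percentage points higher from compound 2 to compound 4 (within the scatter)) and for two (a number 10 percentage points lower from compound 1 to compound 4 (within the scatter)). A double inversion can still matter, however (a number 27.2 percentage points higher from compound 2 to compound 3 (beyond the scatter)), so the number of inverted centres alone does not set the step.

The four compounds do not show how a methyl ester or a primary amide in place of the carboxylic acid would read. They also leave open whether an amine in place of a hydroxyl group would keep these differences between stereoisomers.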